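The compounds below may be only part of what the source reports. "The series", "measured", "known", "first", "only" and "open" are said of these compounds alone.

Compound 3 `O=C1CSC(N2N=C(c3ccc(Br)cc3)CC2c2ccc3ccccc3c2)=N1` gives 18200 nM in a functional assay on HepG2 cells (Homo sapiens) for inhibition, read by CCK-8 assay, with a stated time of 48 h (on this read-out lower numbers stand for stronger inhibition and higher numbers for weaker inhibition), the highest of the three numbers at hand, though each of them lies within the scatter of the others: compound 2 `c1ccc(C2=NN(C3=NC(c4ccccc4)CS3)C(c3ccc4ccccc4c3)C2)cc1` gives 17200 nM and compound 1 `Cc1ccc(C2=NN(C3=NC(c4ccccc4)CS3)C(c3ccc4ccccc4c3)C2)cc1` gives 14700 nM. Compound 4 `Brc1ccc(C2=NN(C3=NC(c4ccccc4)CS3)C(c3ccc4ccccc4c3)C2)cc1` differs from compound 3 by a group of 11 heavy atoms (9 carbon, 1 nitrogen, 1 sulfur; one five-membered non-aromatic ring with 2 hetero atoms, one six-membered aromatic ring of carbon only) in place of a group of 6 heavy atoms (3 carbon, 1 nitrogen, 1 oxygen, 1 sulfur; one five-membered non-aromatic ring with 2 hetero atoms), on an amine nitrogen in a ring. Among the compounds with values here, the only measured step, a 1.2-fold higher number from compound 1 to compound 2 (0.07 log units; within the scatter), concerns a different position and does not bear directly on this exchange. Compounds 1 and 2 already carry the entering group on that ring nitrogen and their numbers sit close to that of compound 3. Compound 4 is therefore expected to remain near this cluster, with an expected step of a 1.1-fold lower number from compound 3 to compound 4 (0.06 log units; within the scatter). The estimate for compound 4 is 16000 nM, in the range 8000 nM to 32000 nM.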

Compound 4, half-maximal inhibitory concentration: 20300 nM
For compound 4 the middle estimate is 1.3-fold (0.10 log units) below the measured one; low and high end bracket the measured number.
By their numbers in this assay, from the lowest: compounds 1, 2, 3 and 4 (each within the scatter of the next).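

In this assay the exchange on the amine nitrogen in a ring gives a 1.1-fold higher number from compound 3 to compound 4 (0.05 log units; within the scatter) and so does not separate the group of 11 heavy atoms from the group of 6 heavy atoms. On the aromatic carbon, bromo in place of hydrogen gives a 1.2-fold higher number from compound 2 to compound 4 (0.07 log units; within the scatter) and bromo in place of methyl gives a 1.4-fold higher number from compound 1 to compound 4 (0.14 log units; within the scatter) and so neither exchange separates these groups. Nothing at hand offers an explanation for these numbers. From the compounds shown here alone, whether an amine or a carboxylic acid on that aromatic carbon would move the number beyond the scatter remains open.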